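Swapping a Pyridinylmethyl Amine for a Piperidinylethyl Amine

The source may report more compounds than this note shows. Statements on the series, on what has been measured and on what is new or still open speak of the compounds shown alone.

Three sulfamate compounds have been measured in an assay on HEK293 cells for inhibition of Steryl-sulfatase (Homo sapiens), tested at 0.1 uM; on this read-out higher numbers stand for a stronger effect at the one concentration tested and lower numbers for a weaker effect. Compound 1 `NS(=O)(=O)Oc1ccc2c(c1)CN(C(=O)c1cccc(N3CCC(Cc4ccccc4)CC3)c1)CC2` gives 1.4% in this assay. Compound 3 `NS(=O)(=O)Oc1ccc2c(c1)CN(C(=O)c1cccc(N3CCc4ccccc4C3)c1)CC2` gives 24.1%. Compound 2 `CCN(Cc1cccnc1)c1ccc(C(=O)N2CCc3ccc(OS(N)(=O)=O)cc3C2)cc1` gives 35.7%, the highest of the three numbers; its gap to compound 3 and its larger gap to compound 1 both lie beyond the usual scatter of this assay, so compound 2 is the strongest of the three at the single concentration tested.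

The next compound, compound 4 `CN(CCN1CCCCC1)c1ccc(C(=O)N2CCc3ccc(OS(N)(=O)=O)cc3C2)cc1`, keeps the whole of compound 2 except for one group on an aromatic carbon of a six-membered aromatic ring of carbon only, para to a large group. The change is methyl(2-(piperidin-1-yl)ethyl)amino in place of ethyl((pyridin-3-yl)methyl)amino on an aromatic carbon. The group that leaves and the group that enters match each other in what is counted for them; the difference is that an aromatic ring with one hetero atom gives way to a non-aromatic ring with one hetero atom.

Among the compounds with values here, no measured pair shows this exact change, so the size of the step can only be guessed. A small downward step, or none beyond the scatter, seems the most likely outcome in this assay. Compound 4 is therefore expected to give about 25%, within a range of 5% to 50%, which means an expected step of a number 10.7 percentage points lower from compound 2 to compound 4 (beyond the scatter).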

Compound 4, a percentage reported as inhibition, at one concentration (the size of the read-out at that concentration, not a potency): 0.3%
Beside the measured number, compound 4's estimate is 24.7 percentage points above it, outside the stated range (below it).
By their numbers in this assay, from the lowest: compounds 4 and 1 (each within the scatter of the next); then compound 3; then compound 2.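

At the aromatic carbon para to a large group, the swap of ethyl((pyridin-3-yl)methyl)amino for methyl(2-(piperidin-1-yl)ethyl)amino gives in this assay a number 35.4 percentage points lower from compound 2 to compound 4 (beyond the scatter) and counts as a large step. The two groups have the same counts of heavy atoms, carbon, nitrogen, hydrogen-bond donors and hydrogen-bond acceptors and carry no net charge, so these counts alone do not tell how well a group is tolerated at this position. The visible difference is an aromatic ring with one hetero atom giving way to a non-aromatic ring with one hetero atom, but no measurement is available that explains the size of this step.

The ring, the chain leading to it and the small alkyl group on the amine nitrogen all change in this one swap, so the compounds shown leave open which of these parts accounts for the step. A 2-(pyridin-3-yl)ethyl chain, which would pair the aromatic ring with the longer chain, or a benzyl group in place of the (pyridin-3-yl)methyl group would help separate these parts.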